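The source may hold more compounds than are shown below. What is called first, only, known or untested is meant among the compounds shown, and "the series" means these compounds.

Measured so far in a functional assay on HeLa cells (Homo sapiens) for cytotoxicity, read by sulforhodamine B assay; on this read-out lower numbers stand for stronger inhibition and higher numbers for weaker inhibition:

compound 1, `CSc1ccc(N(C)c2nc(C)nc3ccccc23)cc1`, gives 1.3 nM
compound 2, `COc1cccc2cc(N(C)c3nc(C)nc4ccccc34)ccc12`, gives 2.5 nM
compound 3, `CSc1ccc(N(C)c2nc(Cl)nc3ccccc23)cc1`, gives 5 nM

Compound 3 arises from compound 1 by one change, (chloro in place of methyl on an aromatic carbon), and this change made a step of a 3.8-fold higher number from compound 1 to compound 3 (0.59 log units; beyond the scatter). Compound 1 and compound 2 share the part of the molecule that carries this change but differ in the rest; that difference between the two cores is not broken down here. The values of compound 1 and compound 2 lie within the scatter of each other, so nothing can be said about their order.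

Compound 4, `COc1cccc2cc(N(C)c3nc(Cl)nc4ccccc34)ccc12`, is the not yet measured partner of compound 2: it differs from compound 2 by chloro in place of methyl on an aromatic carbon, the same change that separates compound 3 from compound 1, at a place described in exactly the same words. Within the data shown here, because the one measured example of this change gave a 3.8-fold higher number from compound 1 to compound 3 (0.59 log units; beyond the scatter), a step of about a 3.6-fold higher number from compound 2 to compound 4 (0.56 log units; beyond the scatter) is expected from compound 2 to compound 4, the modest loss carrying over to the new core. On that basis compound 4 is estimated to give about 9 nM in this assay, most likely between 4 nM and 25 nM.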

Compound 4, half-maximal inhibitory concentration: 2.8 nM
For compound 4 the middle estimate is 3.2-fold (0.51 log units) above the measured one, outside the stated range (below it).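

On the core of compound 2, chloro in place of methyl on the aromatic carbon left almost no mark in this assay, with a 1.1-fold higher number from compound 2 to compound 4 (0.05 log units; within the scatter), so the modest loss seen on the other core did not carry over, and the two steps differ: the same change on two cores in this assay, a 3.8-fold higher number (0.59 log units; beyond the scatter) from compound 1 to compound 3 and a 1.1-fold higher number (0.05 log units; within the scatter) from compound 2 to compound 4, 3.4-fold (0.54 log units) apart, beyond the scatter of two such steps

A step measured on one core in this series is therefore no safe guide to the same change on the other, and each core has to be measured for itself. What this does not show is why the two cores respond differently, and two pairs of compounds give no general rule for the series.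

At this place on the ring, the compounds shown carry only methyl or chloro, so it stays open how an amine or a longer alkyl chain there would fare on either core. As far as these compounds go, it also stays open whether a third core would follow the pair compound 1 and compound 3 or the pair compound 2 and compound 4.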